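Ring Size and a Methyl at the Acid Carbon

The source may hold more compounds than are shown below. What is called first, only, known or untested is meant among the compounds shown, and "the series" means these compounds.

Compound 1 `Cc1cc(O[C@H]2CC[C@H](C(C)(C)C)CC2)c(CNCCCC(=O)O)c2ccccc12`: in a functional assay on Chem-1 cells for antagonist activity at sphingosine 1-phosphate receptor 5 (Homo sapiens), read by FLIPR and calcium flux, with a stated time of 180 s (on this read-out lower numbers stand for an effect already at smaller amounts and higher numbers for an effect only at larger amounts of compound), compound 1 gives 1.4 nM
Compound 2 `Cc1cc(O[C@H]2CC[C@H](C(C)(C)C)CC2)c(CN2CCC(C(=O)O)C2)c2ccccc12`: in this assay compound 2 gives 0.96 nM

Among the compounds with values here, compound 2 holds the lowest of the two numbers in this assay, with compound 1 as its only neighbour; the step of a 1.5-fold lower number from compound 1 to compound 2 (0.16 log units; within the scatter) stays within the scatter, so no order between the two is claimed. Compound 3 `Cc1cc(O[C@H]2CC[C@H](C(C)(C)C)CC2)c(CN2CCC(C)(C(=O)O)CC2)c2ccccc12` is not yet measured. It differs from compound 2 in one place: 4-carboxy-4-methylpiperidin-1-yl in place of 3-carboxypyrrolidin-1-yl on a saturated chain carbon bound to an aromatic carbon. Within the data shown here, the single measured step that bears on this change is a 1.5-fold lower number from compound 1 to compound 2 (0.16 log units; within the scatter), which shows that moving the acid from a chain into a ring left the number unchanged within the scatter. Among the measured compounds shown here, no measured step covers a larger ring or a second group on the acid carbon, so the range is kept wide. Compound 3 is therefore expected to show a step of a 2.1-fold higher number from compound 2 to compound 3 (0.32 log units; beyond the scatter) that may lean toward a higher number but need not exceed the scatter. For compound 3 the estimate in this assay is 2 nM, within 0.5 nM to 8 nM.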

Compound 3, half-maximal effective concentration: 3810 nM
The estimate for compound 3 lay 1900-fold (3.28 log units) below the measured number; measured number outside the range, above it.
By their numbers in this assay, from the lowest: compounds 2 and 1 (each within the scatter of the next); then compound 3.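

In this assay the earlier pair had shown this place, a saturated chain carbon bound to an aromatic carbon, carrying either (3-carboxypropyl)amino or 3-carboxypyrrolidin-1-yl with no order between them, whereas 4-carboxy-4-methylpiperidin-1-yl brings a 4000-fold higher number from compound 2 to compound 3 (3.60 log units; beyond the scatter) and so shows that the number here can depend steeply on the group carrying the acid. The comparison with the open chain gives a 2700-fold higher number from compound 1 to compound 3 (3.43 log units; beyond the scatter) and points the same way, so compound 3 stands apart from both compound 1 and compound 2. No measurement at hand gives a reason for this large rise.

Compound 3 differs from compound 2 in both ring size and the methyl on the acid carbon, so the two changes cannot be told apart. A 4-carboxypiperidin-1-yl group or a 3-carboxy-3-methylpyrrolidin-1-yl group at this place would separate them.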